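Swapping a methylated ethenyl arm for an ethynyl arm

A few compounds are considered here, and "the series" means these few. Any claim that something is new, unique, unknown or untested is made for them only; others in the source may bear on it.

Measured in a functional assay on MX1 cells (Homo sapiens) for inhibition, read by MTT assay, with a stated time of 120 h; on this read-out lower numbers stand for stronger inhibition and higher numbers for weaker inhibition:
- Compound 1 `CNC(=O)/C=C/c1ccc(NC(=O)Nc2ccc(Cl)c(C(F)(F)F)c2)cc1` gives 13800 nM
- Compound 2 `CNC(=O)/C=C(\C)c1ccc(NC(=O)Nc2ccc(Cl)c(C(F)(F)F)c2)cc1` gives > 50000 nM, a limit and not a number
- Compound 3 `CNC(=O)C#Cc1ccc(NC(=O)Nc2ccc(Cl)c(C(F)(F)F)c2)cc1` is not yet measured

Compound 2 has no exact number in this assay and stands only at a limit: the limit of > 50000 nM in this assay, at which 1 of the 2 values shown sits. Compound 3 differs from it as follows: 2-(methylcarbamoyl)ethynyl in place of 1-methyl-2-(methylcarbamoyl)ethenyl on an aromatic carbon. In words, 2-(methylcarbamoyl)ethynyl comes in place of 1-methyl-2-(methylcarbamoyl)ethenyl on an aromatic carbon.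

Going by the values given here, one measured step bears on this change: an at least 3.6-fold higher number from compound 1 to compound 2 (0.55 log units; beyond the scatter), which lies beyond the scatter. It came with 1-methyl-2-(methylcarbamoyl)ethenyl replacing 2-(methylcarbamoyl)ethenyl. Compound 3 has no such methyl, so a move towards a lower number is expected, with compound 1 at 13800 nM as the closest guide. The expected step is an at least 2.5-fold lower number from compound 2 to compound 3 (0.39 log units; beyond the scatter). For compound 3 the estimate is 20000 nM, with an expected range from 7000 nM to 50000 nM.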

Compound 3, half-maximal inhibitory concentration: 26400 nM
For compound 3 the middle estimate is 1.3-fold (0.12 log units) below the measured one, and the stated range covers the measured number.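

In this assay, putting 2-(methylcarbamoyl)ethynyl in place of 2-(methylcarbamoyl)ethenyl gives a 1.9-fold higher number from compound 1 to compound 3 (0.28 log units; within the scatter), so a triple bond in this arm cannot be told apart from the double bond on this read-out. The change away from the methylated arm gives an at least 1.8-fold lower number from compound 2 to compound 3 (0.27 log units; that floor lies within the scatter), and with that floor inside the scatter, this step alone does not separate the two compounds. Compound 2 stands only at a limit, so that step has a floor and no exact size: the limit of > 50000 nM in this assay, at which 1 of the 3 values shown sits.

Still open, from the compounds shown here alone, is whether a saturated two-carbon chain in this position, with neither a double nor a triple bond, would read like these arms. Also open, going by these compounds, is how the ethynyl arm would behave with a carboxylic acid or a nitrile in place of the methylcarbamoyl end.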